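Urea aryl change in a weakly active series

This account rests on a few compounds, and the source may have more. Where it says the series, first, only, none or still open, it means among the compounds named here.

Compound 1 `COc1ccc(NC(=O)Nc2nc(Sc3c[nH]c4ccccc34)cc(N3CCN(c4ccccn4)CC3)n2)cc1` gives 33400 nM in a functional assay on PC-3 cells (Homo sapiens) for inhibition, with a stated time of 72 h (on this read-out lower numbers stand for stronger inhibition and higher numbers for weaker inhibition), the highest of the two numbers seen; compound 2 `COc1ccc(NC(=O)Nc2nc(Sc3c[nH]c4ccccc34)cc(N3CCCC3)n2)cc1` gives 21500 nM in this assay, and the step of a 1.6-fold lower number from compound 1 to compound 2 (0.19 log units; within the scatter) concerns a different part of the shared core. Compound 3 `Cc1cc(Cl)ccc1NC(=O)Nc1nc(Sc2c[nH]c3ccccc23)cc(N2CCN(c3ccccn3)CC2)n1` carries 4-chloro-2-methylphenyl in place of 4-methoxyphenyl on an amide-type nitrogen. For the measured compounds named here, no measured step touches this amide-type nitrogen, so the one step seen, itself within the scatter, offers only a hint that the series sits in a narrow band. For compound 3 the estimate is 30000 nM, between 10000 nM and 90000 nM, with a 1.1-fold lower number from compound 1 to compound 3 (0.05 log units; within the scatter) expected to remain within the scatter.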

Compound 3, half-maximal inhibitory concentration: 19800 nM
Compound 3: the middle estimate sits 1.5-fold (0.18 log units) above what was measured; the measured number falls inside the stated range.
By their numbers in this assay, from the lowest: compounds 3, 2 and 1 (each within the scatter of the next).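

For the compounds shown here, replacing 4-methoxyphenyl with 4-chloro-2-methylphenyl on the amide-type nitrogen gives in this assay a 1.7-fold lower number from compound 1 to compound 3 (0.23 log units; within the scatter) and is the first step read at this position. Losing the methoxy oxygen and bringing in chlorine and methyl therefore leaves compound 3 within the scatter of compound 1. No evidence bears on this result. Open, going by these compounds, is whether an amine or a carboxylic acid on this phenyl ring, or a longer alkyl chain in its place, would give a step beyond the scatter. Also open, on these data alone, is how 4-chloro-2-methylphenyl behaves alongside pyrrolidin-1-yl.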